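Methoxy for Methyl on the Sulfonyl Aryl of Compound 3

This account rests on a few compounds, and the source may have more. Where it says the series, first, only, none or still open, it means among the compounds named here.

Three compounds sharing one core were tested in a functional assay on HepG2 cells (Homo sapiens) for antiproliferative activity, with a stated time of 72 h; on this read-out lower numbers stand for an effect already at smaller amounts and higher numbers for an effect only at larger amounts of compound. Compound 1 `COc1ccc(-c2cc(=O)c3c(OC)cc(OC)cc3n2S(=O)(=O)c2cccc([N+](=O)[O-])c2)cc1` reaches only the limit > 39600 nM. Compound 2 `COc1ccc(-c2cc(=O)c3c(OC)cc(OC)cc3n2S(=O)(=O)c2ccc(C)c([N+](=O)[O-])c2)cc1` likewise gives only the limit > 51700 nM. Compound 3 `COc1ccc(-c2cc(=O)c3c(OC)cc(OC)cc3n2S(=O)(=O)c2ccc(C)cc2)cc1` stands at the limit > 44800 nM as well. The steps a step that the two limits leave unreadable from compound 1 to compound 2, a step that the two limits leave unreadable from compound 1 to compound 3 and a step that the two limits leave unreadable from compound 2 to compound 3 cannot be sized, since (the limit of > 39600 nM in this assay, at which 1 of the 3 values shown sits), the limit of > 44800 nM in this assay, at which 1 of the 3 values shown sits, and the limit of > 51700 nM in this assay, at which 1 of the 3 values shown sits, are all limits. Compound 4 `COc1ccc(-c2cc(=O)c3c(OC)cc(OC)cc3n2S(=O)(=O)c2ccc(OC)cc2)cc1` arises from compound 3 by methoxy in place of methyl on an aromatic carbon. Within the data shown here, none of the measured steps concerns this change, and none of them was readable; in this assay a step that the limit leaves unreadable from compound 3 to compound 4 is expected, most likely ending again at a limit. Compound 4 is accordingly estimated at 60000 nM, between 30000 nM and 150000 nM.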

Compound 4, half-maximal effective concentration: > 82700 nM
Compound 4: a limit, no number (the forecaster's own chance of this, stated with the estimate: 85%); middle value at least 1.3-fold (0.13 log units) from the limit.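

Among these compounds, compound 4 gives only the limit > 82700 nM, so no step from compound 1, compound 2 or compound 3 to compound 4 can be read. The compounds shown leave open whether any change on the sulfonyl aryl group yields a measurable effect.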